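The source may hold more compounds than are shown below. What is called first, only, known or untested is meant among the compounds shown, and "the series" means these compounds.

Measured so far:
compound 1, `COc1cc(-n2cccc2C(=O)O)ccc1Nc1ncc(Cl)c(Nc2ccccc2NS(C)(=O)=O)n1`: in a functional assay on KARPAS-299 cells (Homo sapiens) for antiproliferative activity, read by MTT assay, with a stated time of 4 h (on this read-out higher numbers stand for weaker inhibition and lower numbers for stronger inhibition), compound 1 gives 90 nM
compound 2, `CCN1CCN(C(=O)c2cccn2-c2ccc(Nc3ncc(Cl)c(Nc4ccccc4NS(C)(=O)=O)n3)c(OC)c2)CC1`: in this assay compound 2 gives 1410 nM

Among the measured compounds shown here, compound 2 stands highest of the two numbers measured; its only neighbour is compound 1, and the single measured step, a 16-fold higher number from compound 1 to compound 2 (1.19 log units; beyond the scatter), separates them. That step replaced a hydroxy group on the carbonyl carbon with a nitrogen-linked ring and raised the number by a large margin.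

Compound 3, `COc1cc(-n2cccc2C(=O)N(C)C)ccc1Nc1ncc(Cl)c(Nc2ccccc2NS(C)(=O)=O)n1`, differs from compound 2 in one place: dimethylamino in place of 4-ethylpiperazin-1-yl on a carbonyl carbon. The change keeps an amide nitrogen on that carbonyl but drops the ring, so it partly undoes the earlier step, and a number between those of compound 1 and compound 2 is expected, though with wide uncertainty because only a 16-fold higher number from compound 1 to compound 2 (1.19 log units; beyond the scatter) informs it. Compound 3 is therefore estimated at 550 nM, with a range from 180 nM to 1700 nM. This expected movement corresponds to a 2.6-fold lower number from compound 2 to compound 3 (0.41 log units; beyond the scatter).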

Compound 3, half-maximal inhibitory concentration: 780 nM
Estimate against measurement, compound 3: 1.4-fold (0.15 log units) below, within the range that was stated.
By their numbers in this assay, from the lowest: compound 1; then compounds 3 and 2 (each within the scatter of the next).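

In this assay the change to dimethylamino on the carbonyl carbon gives a 1.8-fold lower number from compound 2 to compound 3 (0.26 log units; within the scatter) and so removing the whole 4-ethylpiperazin-1-yl ring leaves a difference no larger than repeat measurements can produce. Measured against the hydroxy group, the same dimethylamino gives an 8.7-fold higher number from compound 1 to compound 3 (0.94 log units; beyond the scatter) and so, in these three compounds, the wide gap goes with replacing hydroxy by an amide nitrogen, with or without the ring, and not with the ring itself. Nothing measured here explains why the carboxylic acid and the two amides differ in this way.

The compounds shown leave open whether a simple primary amide, which keeps hydrogens on the nitrogen, or a methyl ester, which has no nitrogen at all, would stay close to the acid. They also leave open whether an amine on a longer chain attached to the amide nitrogen would behave like dimethylamino.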